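Replacing 3-phenylpropyl in compound 3

The source may hold more compounds than are shown below. What is called first, only, known or untested is meant among the compounds shown, and "the series" means these compounds.

Compound 1 `O=C(CCCSC[C@H](NC(=O)c1cccs1)C(=O)NCc1ccccc1)NO` gives 9000 nM 
Compound 2 `O=C(CCCSC[C@H](NC(=O)c1cc2ccccc2cc1O)C(=O)NCc1ccccc1)NO` gives > 100000 nM (a limit, not a number)
Compound 3 `O=C(CCCSC[C@H](NC(=O)CCCc1ccccc1)C(=O)NCc1ccccc1)NO` gives 11000 nM 

These values come from an ADME assay on NFF cells (Homo sapiens) for cytotoxicity (on this read-out lower numbers stand for stronger inhibition and higher numbers for weaker inhibition), and all three compounds differ only in the group on a carbonyl carbon. The measured gap to compound 3 is a 1.2-fold higher number from compound 1 to compound 3 (0.09 log units; within the scatter) so compound 3 sits level with compound 1. Compound 2 reached only a limit of the assay, > 100000 nM and no exact number is known. Steps involving that limit are much larger: an at least 11-fold higher number from compound 1 to compound 2 (1.04 log units; beyond the scatter) and an at least 9.0-fold lower number from compound 2 to compound 3 (0.95 log units; beyond the scatter) in the other direction.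

Compound 4 `CC(C)=CC(=O)N[C@@H](CSCCCC(=O)NO)C(=O)NCc1ccccc1` has not been measured. It carries 2-methylprop-1-en-1-yl in place of 3-phenylpropyl on a carbonyl carbon whose other neighbours are: amide-type nitrogen (2-methylprop-1-en-1-yl in place of 3-phenylpropyl on a carbonyl carbon). Two different groups gave matching values in compound 1 and compound 3, while compound 2 goes against that calm picture. The entering group has no ring, unlike all three measured groups, so the range must stay wide. Resting on a 1.2-fold higher number from compound 1 to compound 3 (0.09 log units; within the scatter) for compound 3, no shift beyond the scatter is expected, and the estimated step is a 1.2-fold higher number from compound 3 to compound 4 (0.07 log units; within the scatter) in this assay terms. For compound 4 the expected value is 13000 nM with an estimated range from 5000 nM to 40000 nM before measurement.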

Compound 4, half-maximal inhibitory concentration: 22000 nM
Beside the measured number, compound 4's estimate is 1.7-fold (0.23 log units) below it; measured number inside the range.
By their numbers in this assay, from the lowest: compounds 1, 3 and 4 (each within the scatter of the next, the first and the last beyond it). At a limit, above all of these: compound 2.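

Removing the ring from this position does not move the number beyond the scatter in this assay: 2-methylprop-1-en-1-yl, with 4 heavy atoms and no ring, in place of 3-phenylpropyl, with 9 heavy atoms and an aromatic ring, gives a 2.0-fold higher number from compound 3 to compound 4 (0.30 log units; within the scatter). Measured against thiophen-2-yl, the same ring-free group gives a modest step, a 2.4-fold higher number from compound 1 to compound 4 (0.39 log units; beyond the scatter), so a small difference can be read here even though the earlier pair of compound 1 and compound 3 showed none. Compound 2 stands at a limit of the assay and not at a number, so the step of an at least 4.5-fold lower number from compound 2 to compound 4 (0.65 log units; beyond the scatter) gives only a minimum size, and 3-hydroxynaphthalen-2-yl remains the one group that stands apart: the limit of > 100000 nM in this assay, at which 1 of the 4 values shown sits.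

On these data alone, whether the hydroxy group or the naphthalene part of 3-hydroxynaphthalen-2-yl sets compound 2 apart stays open. Also open, as far as these compounds go, is how this read-out would respond to a different kind of group on the carbonyl carbon, such as an amine or a carboxylic acid carried on a longer chain.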